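A Difluorophenyl Ketone Among Weak Antiproliferative Thioethers

A few compounds are considered here, and "the series" means these few. Any claim that something is new, unique, unknown or untested is made for them only; others in the source may bear on it.

Compound 1 `COc1cc(-c2nnc(SCC(=O)c3ccc(C)cc3)n2N)cc(OC)c1OC`: > 100000 nM, a limit of the assay.
Compound 2 `COc1cc(-c2nnc(SCC(=O)c3ccc(C(F)(F)F)cc3)n2N)cc(OC)c1OC`: > 100000 nM, a limit of the assay.
Compound 3 `COc1cc(-c2nnc(SCC(=O)c3cccc(Br)c3)n2N)cc(OC)c1OC`: 56000 nM.

Among the compounds with values here, in a functional assay on HepG2 cells (Homo sapiens) for antiproliferative activity, read by MTT assay, with a stated time of 48 h (a lower number here means a stronger inhibitor, a higher number a weaker inhibitor), compound 3 gives 56000 nM, the only number in the set. Compound 1 gives > 100000 nM, which is a limit and not a number. Compound 2 gives > 100000 nM, likewise a limit. The steps of an at least 1.7-fold lower number from compound 1 to compound 3 (0.25 log units; that floor lies within the scatter) and an at least 1.7-fold lower number from compound 2 to compound 3 (0.25 log units; that floor lies within the scatter) therefore have floors that sit inside the scatter, and a step that the two limits leave unreadable from compound 1 to compound 2 cannot be read at all; see (the limit of > 100000 nM in this assay, at which 2 of the 3 values shown sit).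

Compound 4 `COc1cc(-c2nnc(SCC(=O)c3ccc(F)c(F)c3)n2N)cc(OC)c1OC` differs from compound 3 by 3,4-difluorophenyl in place of 3-bromophenyl on a carbonyl carbon. Within the data shown here, none of the measured steps exchanges one halogenated phenyl for another, so no step bears directly on this change; the set only shows that compound 3 sits where a number can be read while compound 1 and compound 2 do not. The step of a 1.4-fold higher number from compound 3 to compound 4 (0.15 log units; within the scatter) is therefore expected to be small, in no firm direction. Compound 4 is estimated at 80000 nM, within 25000 nM to 250000 nM.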

Compound 4, half-maximal inhibitory concentration: > 100000 nM
Compound 4: no number, only a limit (the forecaster's own chance of this, stated with the estimate: 45%); at least 1.2-fold (0.09 log units) between middle value and limit.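

In this assay compound 4 gives > 100000 nM, which is a limit and not a number. Placing 3,4-difluorophenyl on the carbonyl carbon in place of 3-bromophenyl gives an at least 1.7-fold higher number from compound 3 to compound 4 (0.25 log units; that floor lies within the scatter), the only readable step here that exchanges one halogenated phenyl for another, and its floor does not separate the two compounds. Compound 3 therefore remains the only one of the four with a number, and the steps among compound 1, compound 2 and compound 4 cannot be read: the limit of > 100000 nM in this assay, at which 3 of the 4 values shown sit.

The compounds shown leave open how far each of the three limits lies from compound 3, and so whether this change has any real size. They also leave open what a 3-chlorophenyl or a 3-aminophenyl group would give on the same carbonyl carbon.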